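Dropping One Chloro from a Dichlorinated Core

This account rests on a few compounds, and the source may have more. Where it says the series, first, only, none or still open, it means among the compounds named here.

Compound 1 `ClCc1cccc(Cn2cnc3c(Cl)nc(Cl)nc32)c1` gives 3230 nM in a functional assay on OVCAR-3 cells (Homo sapiens) for cytotoxicity, read by sulforhodamine B assay, with a stated time of 48 h; a higher number here means a weaker inhibitor of growth, a lower number a stronger inhibitor of growth.
Compound 2 `ClCc1ccccc1Cn1cnc2nc(Cl)nc(Cl)c21` gives 27500 nM.
Compound 3 `ClCc1ccc(Cn2cnc3nc(Cl)nc(Cl)c32)cc1` gives 720 nM.

Among these three numbers compound 1 stands second highest. Compound 3 sits at a lower number, a gap that lies beyond the scatter, and compound 2 sits at a higher number, also beyond the scatter. Compound 4 `ClCc1cccc(Cn2cnc3c(Cl)ncnc32)c1` has not yet been measured. It differs from compound 1 in one place: hydrogen in place of chloro on an aromatic carbon. Going by the values given here, no pair of measured compounds differs in exactly one place, so the size of such a step has no precedent in these data. On these data alone, all three measured compounds keep both chloro groups on the core, so the effect of removing one is untested here; the expectation is that the step in this assay runs toward a higher number, beyond the scatter. The estimate for compound 4 is 8000 nM, with a range from 2500 nM to 25000 nM. The expected step of a 2.5-fold higher number from compound 1 to compound 4 (0.39 log units; beyond the scatter) thus points toward weaker growth inhibition.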

Compound 4, concentration for total growth inhibition: 3020 nM
Compound 4: middle estimate off by 2.6-fold (0.42 log units), on the high side, and the stated range covers the measured number.
By their numbers in this assay, from the lowest: compound 3; then compounds 4 and 1 (each within the scatter of the next); then compound 2.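

Going by these compounds alone, replacing chloro with hydrogen on the aromatic carbon between two ring nitrogen atoms gives a 1.1-fold lower number from compound 1 to compound 4 (0.03 log units; within the scatter) in this assay and is the first comparison here between compounds that differ in one place. In this assay, then, growth inhibition at the level of compound 1 does not depend on this chloro group, at least while the other chloro group on the core remains. The data offer no measured explanation for why this exchange makes no difference beyond the scatter.

Still open, on these data alone, is whether a different replacement on this carbon, such as an amine or a methoxy group, would shift the number beyond the scatter. Also open, as far as these compounds go, is whether the remaining chloro group can be replaced in the same way, and whether removing a chloro group from compound 3 would have as little effect.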